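The source may hold more compounds than are shown below. What is called first, only, known or untested is meant among the compounds shown, and "the series" means these compounds.

Compound 1 `COc1cccc(S(=O)(=O)c2cnc3ccc(Cl)cc3c2N2CCC(C)CC2)c1` — 87%
Compound 2 `CC1CCN(c2c(S(=O)(=O)c3ccc(F)c(F)c3)cnc3ccc(Cl)cc23)CC1` — 72%
Compound 3 `Cc1ccc2ncc(S(=O)(=O)c3ccc(C#N)cc3)c(N3CCC(C)CC3)c2c1` — 55%

Of the compounds shown here, three have been measured in an assay on isolated protein for displacement of a labelled ligand from metabotropic glutamate receptor 5 (Homo sapiens), with a stated time of 60 min, tested at 1 uM; on this read-out higher numbers stand for more inhibition at the one concentration tested (going by the name of the read-out) and lower numbers for less inhibition. Compound 1 gives 87%, compound 2 gives 72%, and compound 3 gives 55%. Compound 3 stands lowest of the three: the nearest is compound 2, whose number is higher by a margin beyond the scatter, and the furthest is compound 1. Going by the values given here, the one step between compounds that differ in a single place, a number 15 percentage points lower from compound 1 to compound 2 (beyond the scatter), is a change on the sulfonyl sulfur, 3,4-difluorophenyl in place of 3-methoxyphenyl.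

Compound 4 `CC1CCN(c2c(S(=O)(=O)c3ccc(C#N)cc3)cnc3ccc(Cl)cc23)CC1` has not yet been measured in this assay. It differs from compound 3 by chloro in place of methyl on an aromatic carbon. Among the compounds with values here, no measured pair shows this exact exchange, so the only step on record, that from compound 1 to compound 2, concerns a different part of the molecule and does not bear directly on it. Compounds 1 and 2 both carry chloro on the core and sit above compound 3, but they also differ from it on the sulfonyl sulfur, so the numbers alone do not separate the two changes. Compound 4 is therefore expected to give about 62%, within 42% to 82%, which means an expected step of a number 7 percentage points higher from compound 3 to compound 4 (within the scatter) that need not exceed the scatter.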

Compound 4, a percentage reported as inhibition, at one concentration (the size of the read-out at that concentration, not a potency): 31%
The estimate for compound 4 lay 31 percentage points above the measured number, outside the stated range (below it).
By their numbers in this assay, from the lowest: compound 4; then compound 3; then compound 2; then compound 1.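

In this assay, the exchange of methyl for chloro on an aromatic carbon of the shared core gives a number 24 percentage points lower from compound 3 to compound 4 (beyond the scatter) with 4-cyanophenyl held on the sulfonyl sulfur, so this place on the core responds to the exchange, and chloro there does not by itself go with a high number. With chloro held fixed, 4-cyanophenyl on the sulfonyl sulfur gives a number 41 percentage points lower from compound 2 to compound 4 (beyond the scatter) when it replaces 3,4-difluorophenyl and a number 56 percentage points lower from compound 1 to compound 4 (beyond the scatter) when it replaces 3-methoxyphenyl, so among these three chloro compounds the group on the sulfonyl sulfur accounts for large steps. Nothing available here accounts for either the fall on the core or the falls on the sulfonyl sulfur.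

The compounds shown pair methyl and chloro only with 4-cyanophenyl, which leaves open whether the same exchange gives a similar step with 3-methoxyphenyl or 3,4-difluorophenyl on the sulfonyl sulfur. They also leave open how a bromo or an ethyl group would read on that aromatic carbon, and how a primary amide would read in place of the nitrile.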